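The source may hold more compounds than are shown below. What is called first, only, known or untested is meant among the compounds shown, and "the series" means these compounds.

Compound 1 `O=C(Nc1ccccc1)c1cccc(/C=C2\CC(=O)N(c3ccccc3)C2=O)c1` — in an ADME assay on SW480 cells (Homo sapiens) for cytotoxicity, read by MTT assay, with a stated time of 72 h (a lower number here means a stronger inhibitor, a higher number a weaker inhibitor), compound 1 reaches only the limit of the assay, not a number: > 100000 nM.
Compound 2 `Cc1ccc(NC(=O)c2cccc(/C=C3\CC(=O)N(c4ccccc4)C3=O)c2)cc1C` — in this assay compound 2 likewise stops at the limit: > 100000 nM.
Compound 3 `COc1ccc(NC(=O)c2cccc(/C=C3\CC(=O)N(c4ccccc4)C3=O)c2)c(C)c1` — in this assay compound 3 too is reported as a limit: > 100000 nM.

Compound 3 therefore stands where both of its companions stand: at the limit, with no number to set it apart from them, as the limit of > 100000 nM in this assay, at which 3 of the 3 values shown sit, records for all three values shown.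

Compound 4 `CSc1cccc(NC(=O)c2cccc(/C=C3\CC(=O)N(c4ccccc4)C3=O)c2)c1` carries one change from compound 3: 3-(methylsulfanyl)phenyl in place of 4-methoxy-2-methylphenyl on an amide-type nitrogen. For the measured compounds named here, two measured steps touch the same amide-type nitrogen and lead into compound 3, namely a step that the two limits leave unreadable from compound 1 to compound 3 and a step that the two limits leave unreadable from compound 2 to compound 3; a third, a step that the two limits leave unreadable from compound 1 to compound 2, runs between the other two compounds. None of them has a readable size, since every value involved is a limit, so none shows that a change of the aryl group on this nitrogen moves the read-out at all within the range the assay can report.

With that, compound 4 is expected to behave like compound 3, and the step of a number no higher from compound 3 to compound 4 (the limit leaves the size open) is estimated to be nothing beyond the scatter. Compound 4 is expected to give about 100000 nM in this assay, within 30000 nM to 300000 nM, most likely again reported only as a limit.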

Compound 4, half-maximal inhibitory concentration: 74300 nM
Compound 4: middle estimate off by 1.3-fold (0.13 log units), on the high side; measured number inside the range.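

In this assay, the aryl group on this amide-type nitrogen can bring a compound of the series to a readable number, which none of the earlier compounds showed: the limit of > 100000 nM in this assay, at which 3 of the 4 values shown sit.

With 3-(methylsulfanyl)phenyl on that nitrogen the record gives an at least 1.3-fold lower number from compound 3 to compound 4 (0.12 log units; that floor lies within the scatter), an at least 1.3-fold lower number from compound 2 to compound 4 (0.12 log units; that floor lies within the scatter) and an at least 1.3-fold lower number from compound 1 to compound 4 (0.12 log units; that floor lies within the scatter), the last being methylsulfanyl in place of hydrogen on an aromatic carbon. Each of these is only a floor set by a limit on the other compound of the pair, so the change is not shown to lie beyond the scatter, and the steps among the three earlier compounds still cannot be read.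

The compounds shown leave open whether the sulfur itself counts, which a 3-methoxyphenyl or 3-methylphenyl group on the same nitrogen would help to settle. Also open, as far as these compounds go, is how an amine or a carboxylic acid on this aryl ring would read, and whether a longer chain on the sulfur, such as ethylsulfanyl, would carry the number further from the limit.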